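Removing a second hydroxy from compound 1 and the expected change in inhibition

A few compounds are considered here, and "the series" means these few. Any claim that something is new, unique, unknown or untested is made for them only; others in the source may bear on it.

For the measured compounds named here, compound 1 `Oc1cccc(-c2ccc3c(-c4cncnc4)c(O)ccc3c2)c1` is the only compound with a measured number in an assay for binding affinity to 17-beta-hydroxysteroid dehydrogenase type 2 (Homo sapiens), read by scintillation counting, with a stated time of 10 min, tested at 1 uM; a higher number here means more inhibition at the concentration tested (going by the name of the read-out), a lower number less inhibition: compound 1 gives 85%. Compound 2 `Oc1cccc(-c2ccc3c(-c4cncnc4)cccc3c2)c1` is reported only as a limit of the assay, < 10%, a point at which (the limit of < 10% in this assay, at which 1 of the 2 values shown sits). Going by the values given here, the step of a number at least 75 percentage points lower from compound 1 to compound 2 (beyond the scatter) is the sole measured comparison, and it concerns hydrogen in place of hydroxy on an aromatic carbon of the shared core.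

Compound 3 `Oc1ccc2cc(-c3ccccc3)ccc2c1-c1cncnc1` differs from compound 1 by hydrogen in place of hydroxy on an aromatic carbon. This is the same kind of change as the measured step, but at a different ring, so the measured step bears on it only as an analogy. Among the compounds with values here, a step downward in this assay beyond the scatter is expected, though likely smaller than the one to compound 2, since the hydroxy of the core is untouched in compound 3. Compound 3 is therefore estimated at 45%, within 10% to 80%, meaning an expected step of a number 40 percentage points lower from compound 1 to compound 3 (beyond the scatter).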

Compound 3, a percentage reported as inhibition, at one concentration (the size of the read-out at that concentration, not a potency): < 10%
Compound 3 gave a limit, no number; the forecaster's own chance of this, stated with the estimate: 20%; middle value at least 35 percentage points away from the limit.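

Replacing the hydroxy of the 3-hydroxyphenyl group with hydrogen brings a number at least 75 percentage points lower from compound 1 to compound 3 (beyond the scatter) in this assay. The earlier step, a number at least 75 percentage points lower from compound 1 to compound 2 (beyond the scatter), showed such a loss only for the hydroxy on the shared core, whereas this result shows that the hydroxy on the other ring cannot be spared either: among the compounds shown, inhibition survives only with both hydroxy groups in place. The reading for compound 3, < 10%, is a limit of the assay and not a number.

Which of the two hydroxy groups contributes more cannot be read, since both removals end at the same limit: the limit of < 10% in this assay, at which 2 of the 3 values shown sit. Whether an amine or a methoxy group at the place of the hydroxy on an aromatic carbon would retain the inhibition remains open.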